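Swapping the amine on a dithiocarbamate: what to expect

The compounds below may be only part of what the source reports. "The series", "measured", "known", "first", "only" and "open" are said of these compounds alone.

Three compounds sharing one core were tested in a functional assay on HeLa cells (Homo sapiens) for antiproliferative activity, read by CCK-8 assay, with a stated time of 72 h, tested at 2 uM; a lower number here means a weaker effect, a higher number a stronger effect of the compound at the concentration tested. Compound 1 `Nc1ccccc1NC(=O)c1ccc(CSC(=S)N2CCN(C(c3ccccc3)c3ccccc3)CC2)cc1` gives 8%, compound 2 `CN(Cc1ccncc1)C(=S)SCc1ccc(C(=O)Nc2ccccc2N)cc1` gives 29.5%, and compound 3 `Nc1ccccc1NC(=O)c1ccc(CSC(=S)N(Cc2ccccc2)Cc2ccccc2)cc1` gives 1%. Among these three numbers compound 2 stands highest: compound 1 lies a distance below it that is beyond the usual scatter, and compound 3 lies further below still, also beyond the scatter. No pair of these compounds differs in only one place, so no single change can be tied to a single shift in the numbers.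

Compound 4 `CN1CCN(C(=S)SCc2ccc(C(=O)Nc3ccccc3N)cc2)CC1` has not yet been measured in this assay. It differs from compound 2 in one place: 4-methylpiperazin-1-yl in place of methyl((pyridin-4-yl)methyl)amino on a thiocarbonyl carbon. The two measured compounds that carry a different group on that same thiocarbonyl carbon, compound 1 and compound 3, both sit low, so a fall from compound 2 to compound 4 is expected, of modest size, though it may not exceed the scatter. The estimated step from compound 2 to compound 4 is a number 14.5 percentage points lower from compound 2 to compound 4 (beyond the scatter). Compound 4 is expected to give about 15%, within a range from 2% to 35%.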

Compound 4, a percentage reported as inhibition, at one concentration (the size of the read-out at that concentration, not a potency): 52.6%
Beside the measured number, compound 4's estimate is 37.6 percentage points below it; the measured number lies above the stated range.
By their numbers in this assay, from the lowest: compounds 3 and 1 (each within the scatter of the next); then compound 2; then compound 4.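

Within the data shown here, this is the first single change with a readable result: with 4-methylpiperazin-1-yl in place of methyl((pyridin-4-yl)methyl)amino on a thiocarbonyl carbon, this assay gives a number 23.1 percentage points higher from compound 2 to compound 4 (beyond the scatter) at the one concentration tested. It shows that the group on this carbon can move the read-out upward from compound 2, and that compound 4 keeps a clear effect without the six-membered aromatic ring. No measurement shown here explains why the number rises.

The swap alters several features at once, replacing an aromatic ring with a non-aromatic one, changing the number of heavy atoms and moving the nitrogens, so the feature that matters remains unresolved. Morpholin-4-yl or unsubstituted piperazin-1-yl on the same carbon would help separate these features, and a full concentration series would be needed to say whether the stronger effect of compound 4 at this one concentration holds at others.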